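The compounds below may be only part of what the source reports. "The series", "measured", "known", "first", "only" and "open" are said of these compounds alone.

Of the compounds shown here, two sharing one core have been measured in a functional assay on A549 cells (Homo sapiens) for inhibition, read by MTT assay, with a stated time of 72 h; a lower number here means a stronger inhibitor of growth, a higher number a weaker inhibitor of growth. Compound 1, `CCN(CC)C(=S)Sc1c(-c2ccccc2)[nH]c2ccc(Br)cc12`, gives 31000 nM there. Compound 2, `CCOC(=O)C1CCN(C(=S)Sc2c(-c3ccc(Br)cc3)[nH]c3ccc(C)cc23)CC1`, gives 37000 nM in this assay. On these numbers compound 1 and compound 2 lie within the scatter of each other, so neither stands apart from the other.

Compound 3, `CCN(CC)C(=S)Sc1c(-c2ccc(Br)cc2)[nH]c2ccc(Br)cc12`, has not yet been measured in this assay. It differs from compound 1 in one place: bromo in place of hydrogen on an aromatic carbon. Going by the values given here, no measured pair differs by exactly this change, so the data give no direct guide to its size. Compound 2 already carries a 4-bromophenyl group and gives 37000 nM, close to compound 1, which points to no large effect. The step of a 1.1-fold lower number from compound 1 to compound 3 (0.06 log units; within the scatter) is therefore expected to stay within the scatter. Compound 3 is estimated to give 27000 nM in this assay, with a range from 9000 nM to 80000 nM.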

Compound 3, concentration for 50% growth inhibition: 22000 nM
Beside the measured number, compound 3's estimate is 1.2-fold (0.09 log units) above it; measured number inside the range.
By their numbers in this assay, from the lowest: compounds 3, 1 and 2 (each within the scatter of the next).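

In this assay, the change from phenyl to 4-bromophenyl gives a 1.4-fold lower number from compound 1 to compound 3 (0.15 log units; within the scatter), so adding this one bromine atom, para to a large group, leaves the growth-inhibition number within the normal scatter of repeat measurements. Going by these compounds alone, this is the first direct reading of the change: compound 1 and compound 2 differ in more than one place, so compound 2 could not show what the 4-bromophenyl group does on its own. There is no supporting measurement that could explain this result.

From the compounds shown here alone, whether an amine, a carboxylic acid or a longer chain at the same place would move the number beyond the scatter remains open. Going by these compounds, it is also open whether the change from phenyl to 4-bromophenyl would give a similar step with other groups elsewhere on the shared core.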